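Swapping pyrimidin-5-yl for 1H-indol-6-yl in a toxicity test

This account rests on a few compounds, and the source may have more. Where it says the series, first, only, none or still open, it means among the compounds named here.

Of the compounds shown here, two have been measured so far in a toxicity assay on MT4 cells (Homo sapiens) for cytotoxicity, read by MTT assay, with a stated time of 5 days; on this read-out lower numbers stand for higher toxicity in this test and higher numbers for lower toxicity in this test. Compound 2 `Cc1cc(-c2cncnc2)cc(C)c1Nc1ccnc(Nc2ccc(C#N)cc2)n1` gives 6800 nM in this test, and compound 1 `Cc1cnc(Nc2ccc(C#N)cc2)nc1Nc1c(F)cc(-c2ccc(C#N)nc2)cc1F` gives 62000 nM in the same test. Compound 2 therefore holds the lower of the two numbers, by a gap beyond the usual scatter, which makes it the more toxic of the pair here.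

Compound 3 `Cc1cc(-c2ccc3cc[nH]c3c2)cc(C)c1Nc1ccnc(Nc2ccc(C#N)cc2)n1` keeps everything in compound 2 except one group: 1H-indol-6-yl stands in place of pyrimidin-5-yl on an aromatic carbon, meta to two methyl groups. Counted out, the change reads 1H-indol-6-yl in place of pyrimidin-5-yl on an aromatic carbon and nothing else differs.

Within the data shown here, no two measured compounds differ in only one place, so the data give no direct guide to a swap like this one. The number could move either way, with a slight lean toward higher toxicity. The expected change is a 1.4-fold lower number from compound 2 to compound 3 (0.13 log units; within the scatter), a small step toward a lower number that probably stays within the scatter. For compound 3 the estimated value is 5000 nM, with a likely range from 1500 nM to 17000 nM.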

Compound 3, half-maximal cytotoxic concentration: 5800 nM
Beside the measured number, compound 3's estimate is 1.2-fold (0.06 log units) below it; the measured number falls inside the stated range.
By their numbers in this assay, from the lowest: compounds 3 and 2 (each within the scatter of the next); then compound 1.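

In this assay, the change at this position gives a 1.2-fold lower number from compound 2 to compound 3 (0.07 log units; within the scatter), so the two compounds cannot be told apart on this read-out. Among these compounds, this is the first comparison in the set that differs in only one place, and it shows that this aromatic carbon, meta to two methyl groups and para to a large group, can carry either of two quite different groups without a clear shift in the number: a single six-membered ring of 6 heavy atoms, or a fused pair of five- and six-membered rings of 9 heavy atoms that adds a hydrogen-bond donor. No supporting data bear on this result, so the measurements record the outcome of the swap and give no explanation for it.

From the compounds shown here alone, whether a plain phenyl ring, an amine or a carboxylic acid on this same carbon would also leave the number in place remains open. Going by these compounds, it is also open whether 1H-indol-6-yl would behave the same way on the core of compound 1, which differs from compound 2 in more than one place.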